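The source may hold more compounds than are shown below. What is called first, only, known or untested is meant among the compounds shown, and "the series" means these compounds.

Measured compounds and their values in a functional assay on HL-60 cells (Homo sapiens) for cytotoxicity, read by luminescence and CellTiter-Glo, with a stated time of 3 days; a higher number here means a weaker inhibitor, a lower number a stronger inhibitor:

Compound 1, `Cc1ccc(C(=O)Nc2ccc(C#N)cc2)c(O)c1`: 2420 nM
Compound 2, `N#Cc1ccc(NC(=O)c2cc(Cc3ccccc3)ccc2O)cc1`: 1740 nM
Compound 3, `N#Cc1ccc(NC(=O)c2cccc(F)c2O)cc1`: 5390 nM

Compound 3 gives the highest of the three numbers in this assay. Compound 1 lies nearest to it, with a number that stands beyond the scatter below that of compound 3; compound 2 lies furthest, also beyond the scatter. Among these three, compound 3 is thus the weakest inhibitor.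

Compound 4, `N#Cc1ccc(NC(=O)c2ccccc2O)cc1`, has not yet been measured in this assay. It differs from compound 3 in one place: hydrogen in place of fluoro on an aromatic carbon. Among the compounds with values here, nothing measured so far relates two compounds by a single change of this kind, so no step of known size can be leaned on. As far as these compounds go, compounds 1 and 2 both carry other groups on the same ring and both give lower numbers than compound 3, but how much of that belongs to the fluoro alone is unknown.

The number for compound 4 is expected to fall close to that of compound 3, the step of a 1.7-fold lower number from compound 3 to compound 4 (0.23 log units; within the scatter) most likely lying within the scatter. Compound 4 is estimated at 3200 nM, with a range from 1300 nM to 8000 nM.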

Compound 4, half-maximal inhibitory concentration: 4620 nM
For compound 4 the middle estimate is 1.4-fold (0.16 log units) below the measured one, within the range that was stated.
By their numbers in this assay, from the lowest: compounds 2, 1, 4 and 3 (each within the scatter of the next, the first and the last beyond it).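

In this assay, hydrogen in place of fluoro ortho to a hydroxy group makes no readable difference (a 1.2-fold lower number from compound 3 to compound 4 (0.07 log units; within the scatter)), so this position now has a single change of known size, and that change lies within the scatter. Compound 4 also serves as a reference for the other groups on the ring: hydrogen in place of methyl stays within the scatter (a 1.9-fold higher number from compound 1 to compound 4 (0.28 log units; within the scatter)), whereas hydrogen in place of benzyl is a modest step beyond it (a 2.7-fold higher number from compound 2 to compound 4 (0.42 log units; beyond the scatter)). Nothing measured here explains any of these steps.

As far as these compounds go, whether an amine or a carboxylic acid ortho to the hydroxy group would move the number beyond the scatter remains open. So does whether a longer chain, such as phenethyl, on the aromatic carbon that carries benzyl in compound 2 would lower the number further.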